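The source may hold more compounds than are shown below. What is called first, only, known or untested is meant among the compounds shown, and "the series" means these compounds.

Going by the values given here, compound 2 `CCc1ccc2ccn(CCN3CCCN(C)CC3)c2c1` gives 166 nM in an assay on HEK293 cells for binding affinity to 5-hydroxytryptamine receptor 7 (Homo sapiens), read by radioligand binding (on this read-out higher numbers stand for weaker inhibition and lower numbers for stronger inhibition), the higher of the two numbers measured so far; compound 1 `C=Cc1ccc2ccn(CCN3CCCN(C)CC3)c2c1` gives 109 nM, a gap within the scatter. Among the compounds with values here, the one measured step, a 1.5-fold higher number from compound 1 to compound 2 (0.18 log units; within the scatter), stayed within the scatter. Compound 3 `CC(C)c1ccc2ccn(CCN3CCCN(C)CC3)c2c1` carries methyl in place of hydrogen on a saturated chain carbon bound to an aromatic carbon and a saturated chain carbon, the difference that one bond further out reads ethyl to isopropyl. Within the data shown here, only that ethyl step bears on it, and it was within the scatter, so in this assay the expected step is a 1.3-fold higher number from compound 2 to compound 3 (0.10 log units; within the scatter), a drift to a higher number not beyond the scatter. Compound 3 is expected to give 210 nM, range 100 nM to 450 nM.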

Compound 3, inhibition constant: 145 nM
The estimate for compound 3 lay 1.4-fold (0.16 log units) above the measured number; the measured number falls inside the stated range.
By their numbers in this assay, from the lowest: compounds 1, 3 and 2 (each within the scatter of the next).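

In this assay, the change from ethyl to isopropyl gives a 1.1-fold lower number from compound 2 to compound 3 (0.06 log units; within the scatter) and isopropyl in place of vinyl gives a 1.3-fold higher number from compound 1 to compound 3 (0.12 log units; within the scatter) on this aromatic carbon. The added methyl therefore leaves the number within the scatter, and vinyl, ethyl and isopropyl cannot be ordered here. Nothing at hand explains this flat reading. Still open, from the compounds shown here alone, is whether tert-butyl, an amine or a carboxylic acid on this aromatic carbon would move the number beyond the scatter.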